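Shifting methyls on a pyridine ring: metabolic stability

A few compounds are considered here, and "the series" means these few. Any claim that something is new, unique, unknown or untested is made for them only; others in the source may bear on it.

Measured so far:
Compound 1, `CC[C@H](C)[C@@H]1C(=O)N[C@H](C2Cc3ccccc3C2)C(=O)N1[C@@H](C(=O)NC)c1cc(C)cnc1C`, gives 3 mL.min-1.g-1.
Compound 2, `Cc1ccc([C@H](C(=O)N(C)C)N2C(=O)[C@@H](C3Cc4ccccc4C3)NC(=O)[C@H]2CC(C)C)cn1`, gives 11000 mL.min-1.g-1.
Compound 3, `CCC(CC)[C@@H]1C(=O)N[C@H](C2Cc3ccccc3C2)C(=O)N1[C@@H](C(=O)N1CCOCC1)c1ccc(C)nc1`, gives 12 mL.min-1.g-1.

All three were tested in an in vitro ADME assay on microsomes from liver (Homo sapiens) for metabolic stability; on this read-out higher numbers stand for fast clearance and lower numbers for slow clearance. Compound 1 stands lowest of the three numbers, so it is cleared most slowly. The nearest of the others is compound 3, and compound 2 lies far above, well beyond the scatter in both cases. These pairs differ from compound 1 in more than one place, so the three values show only where each lands, not what any single change does.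

The unmeasured compound 4, `CC[C@H](C)[C@@H]1C(=O)N[C@H](C2Cc3ccccc3C2)C(=O)N1[C@@H](C(=O)NC)c1cnc(C)cc1C`, shares every atom with compound 1 and differs only in how they are joined: 4,6-dimethylpyridin-3-yl in place of 2,5-dimethylpyridin-3-yl on a saturated chain carbon bound to an amide-type nitrogen in a ring and a carbonyl carbon. Because compound 1 shows 3 mL.min-1.g-1 in this assay, and the change keeps the same ring and substituent count, the expected step is only a 1.7-fold higher number from compound 1 to compound 4 (0.22 log units; within the scatter). Compound 4 is therefore estimated at 5 mL.min-1.g-1, within the range 2 mL.min-1.g-1 to 15 mL.min-1.g-1.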

Compound 4, intrinsic clearance in microsomes: 7 mL.min-1.g-1
The estimate for compound 4 lay 1.4-fold (0.15 log units) below the measured number, within the range that was stated.
By their numbers in this assay, from the lowest: compound 1; then compounds 4 and 3 (each within the scatter of the next); then compound 2.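

Within the data shown here, replacing 2,5-dimethylpyridin-3-yl with 4,6-dimethylpyridin-3-yl gives the first direct reading of a single change at this position in this assay: there is a 2.3-fold higher number from compound 1 to compound 4 (0.37 log units; beyond the scatter). The same atoms are present in both compounds, so rearranging them within this one group is enough to move the number, though the step is modest. Nothing in the data explains why the number moves in this direction.

From the compounds shown here alone, only these two dimethyl arrangements can be compared directly on this core, so it remains open how a methoxy group or a chlorine atom in place of one methyl would read. Going by these compounds, it is also open whether the same rearrangement would give a similar step alongside a different amide or side chain.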